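The source may report more compounds than this note shows. Statements on the series, on what has been measured and on what is new or still open speak of the compounds shown alone.

In a functional assay on MCF7 cells (Homo sapiens) for antiproliferative activity, read by sulforhodamine B assay, with a stated time of 72 h (on this read-out higher numbers stand for weaker inhibition and lower numbers for stronger inhibition), compound 1 (`FC(F)(F)c1cccc(/C=C\c2cc3ccccc3nc2Cl)c1`) gives 3530 nM and compound 2 (`COc1ccc2nc(Cl)c(/C=C\c3cccc(C(F)(F)F)c3)cc2c1`) gives 2780 nM on the same read-out. For the measured compounds named here, these are the only two numbers so far and they lie within the scatter of each other, so compound 2 cannot be ranked against compound 1.

Compound 3 (`COc1ccc2nc(Cl)c(/C=C\c3cc(C(F)(F)F)cc(C(F)(F)F)c3)cc2c1`) differs from compound 2 at one site (trifluoromethyl in place of hydrogen on an aromatic carbon): trifluoromethyl in place of hydrogen on an aromatic carbon of a six-membered aromatic ring of carbon only, meta to a trifluoromethyl group. Going by the values given here, the single measured step (a 1.3-fold lower number from compound 1 to compound 2 (0.10 log units; within the scatter)) is methoxy in place of hydrogen on an aromatic carbon. Among the compounds with values here, it is a different change at a different site, yet it is the sole guide. Within the data shown here, no measurement so far shows what a change at this site does, so the uncertainty stays wide, and no shift beyond the scatter is expected in this assay for compound 3 on present evidence. The expected step (a 1.1-fold lower number from compound 2 to compound 3 (0.05 log units; within the scatter)) is an estimate only. For compound 3 the estimated value is 2500 nM with an expected range from 800 nM to 8000 nM in this estimate.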

Compound 3, half-maximal inhibitory concentration: 4700 nM
Compound 3: the middle estimate sits 1.9-fold (0.27 log units) below what was measured, and the stated range covers the measured number.
By their numbers in this assay, from the lowest: compounds 2, 1 and 3 (each within the scatter of the next).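

For the compounds shown here, a further trifluoromethyl group, meta to a trifluoromethyl group, is the first change at this position to be read in this assay, and it gives a 1.7-fold higher number from compound 2 to compound 3 (0.23 log units; within the scatter) on this read-out. A second trifluoromethyl group on the same six-membered aromatic ring of carbon only, an entering group of 4 heavy atoms, therefore leaves the antiproliferative read-out within the scatter, so this position accepts a large group without a shift that can be told apart from repeat variation. This single step gives no direction for the position, and no available measurement bears on what lies behind the result.

Whether an amine, a carboxylic acid or a longer chain at this position would move the number beyond the scatter stays open, since trifluoromethyl is the only group shown there. Also open, going by these compounds, is whether the same trifluoromethyl change would read alike on the core of compound 1, which carries hydrogen where compound 2 carries methoxy.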